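This account rests on a few compounds, and the source may have more. Where it says the series, first, only, none or still open, it means among the compounds named here.

Working notes on the thiazole acetic acid series

Three compounds of this series have numbers in an in vitro functional assay on HEK285-7 cells for antagonist activity at prostaglandin D2 receptor 2 (Homo sapiens), read by BRET and beta-arrestin recruitment; on this read-out higher numbers stand for weaker inhibition and lower numbers for stronger inhibition. Compound 1 `Nc1nc(-c2ccc(Cl)cc2)c(CC(=O)O)s1` carries a bare amino group on the shared core, and in this assay compound 1 returns only a limit, > 100000 nM, a value that sits at the limit of > 100000 nM in this assay, at which 1 of the 3 values shown sits. Compound 2 `O=C(O)Cc1sc(C(c2ccccc2)c2ccccn2)nc1-c1ccc(Cl)cc1` replaces that amino group with a phenyl(pyridyl)methyl substituent, and in this assay compound 2 gives 1900 nM. Compound 3 `O=C(O)Cc1sc(C(c2ccc(F)cc2)c2ccc(F)cc2)nc1-c1cccc(F)c1` carries a bis(4-fluorophenyl)methyl group together with a 3-fluorophenyl on the core, and in this assay compound 3 gives 18 nM, the lowest of the two numbers in the set; compound 2 lies far above it, well beyond the scatter. Compound 1 offers only a limit for comparison.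

Compound 4 `O=C(O)Cc1sc(C(c2ccc(F)cc2)c2ccc(F)cc2)nc1-c1ccco1` keeps the bis(4-fluorophenyl)methyl group of compound 3 and differs in one place: furan-2-yl in place of 3-fluorophenyl on an aromatic carbon. Going by the values given here, no measured pair in the set covers this kind of exchange, so the size of the step is open. The six-membered ring leaves and a five-membered ring with one hetero atom enters on the same carbon of the core. The expectation for compound 4 is a modest loss against compound 3, a step of a 2.8-fold higher number from compound 3 to compound 4 (0.44 log units; beyond the scatter), not far beyond the scatter. In this assay compound 4 is estimated at 50 nM, with a range from 12 nM to 250 nM.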

Compound 4, half-maximal inhibitory concentration: 140 nM
Compound 4: the middle estimate sits 2.8-fold (0.45 log units) below what was measured; the range from low to high includes it.
By their numbers in this assay, from the lowest: compound 3; then compound 4; then compound 2. At a limit, above all of these: compound 1.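

In this assay, furan-2-yl in place of 3-fluorophenyl on the aromatic carbon next to the ring nitrogen gives weaker inhibition, with a 7.8-fold higher number from compound 3 to compound 4 (0.89 log units; beyond the scatter). Going by these compounds alone, this is the first exchange in the set confined to one place, and it shows that, with the bis(4-fluorophenyl)methyl group held constant, the group on this carbon affects the read-out and that these two aromatic rings are not interchangeable, although the step remains modest. Nothing measured in these notes bears on the origin of this step.

The exchange alters several features together: a six-membered ring of carbon only gives way to a five-membered ring, a ring oxygen and a hydrogen-bond acceptor enter, and the fluorine leaves, so the compounds shown leave open which of these features accounts for the step. Thiophen-2-yl or unsubstituted phenyl on this carbon, with the bis(4-fluorophenyl)methyl group kept, would help separate the effect of ring size and ring oxygen from that of the fluorine.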